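Aryl exchange on the amine nitrogen of the shared core

The source may report more compounds than this note shows. Statements on the series, on what has been measured and on what is new or still open speak of the compounds shown alone.

Two compounds of the series carry the same core, differing only in the aryl on the amine nitrogen. Compound 1 `S=c1oc(-c2ccc3c(c2)OCCO3)nn1CNc1ccccc1` gives 5140 nM in a functional assay, with a stated time of 6 min; on this read-out lower numbers stand for stronger inhibition and higher numbers for weaker inhibition. Compound 2 `Fc1cc(NCn2nc(-c3ccc4c(c3)OCCO4)oc2=S)cc(F)c1F` gives 2920 nM in the same assay. The step of a 1.8-fold lower number from compound 1 to compound 2 (0.25 log units; within the scatter) lies within the scatter, so compounds 1 and 2 stand together on the numbers at hand; compound 2 has no step beyond the scatter to any other measured compound.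

Compound 3 `S=c1oc(-c2ccc3c(c2)OCCO3)nn1CNc1ccccc1Br` is not yet measured. It differs from compound 2 as follows: 2-bromophenyl in place of 3,4,5-trifluorophenyl on an amine nitrogen

Within the data shown here, the only measured step in this assay, a 1.8-fold lower number from compound 1 to compound 2 (0.25 log units; within the scatter), concerns the same place on the amine nitrogen, and it stayed within the scatter. Among the measured compounds shown here, no measured step covers a bromine on the aryl or the loss of the three fluorines, so nothing points to a change beyond the scatter in either direction. Compound 3 is therefore expected to give a number close to that of compound 2, an expected step of a 1.3-fold higher number from compound 2 to compound 3 (0.11 log units; within the scatter). The estimate for compound 3 is 3800 nM, with a range from 1500 nM to 10000 nM.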

Compound 3, half-maximal inhibitory concentration: 12700 nM
For compound 3 the middle estimate is 3.3-fold (0.52 log units) below the measured one, outside the stated range (above it).
By their numbers in this assay, from the lowest: compounds 2 and 1 (each within the scatter of the next); then compound 3.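

Notes on the aryl at the amine nitrogen: in this assay this position does respond to the choice of aryl, as the 2-bromophenyl change gives a 4.3-fold higher number from compound 2 to compound 3 (0.64 log units; beyond the scatter) and so provides the first step in the series beyond the scatter. The single-place comparison with the unsubstituted phenyl gives a 2.5-fold higher number from compound 1 to compound 3 (0.39 log units; beyond the scatter), so adding the bromine also moves the number upward, whereas a 1.8-fold lower number from compound 1 to compound 2 (0.25 log units; within the scatter) leaves the 3,4,5-trifluorophenyl and the phenyl together; substituents on this aryl therefore do not all behave alike in these three compounds. Nothing at hand bears on why the 2-bromophenyl compound reads higher.

As far as these compounds go, whether this step belongs to bromine specifically or would also appear with a chlorine or a methyl group on the aryl remains open. Also open is whether any replacement at this place, such as a pyridyl or cyclohexyl ring, would give a number beyond the scatter on the lower side of compound 1 and compound 2, since no step of that kind appears among these compounds.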